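HDAC6 inhibition: a pyridyl for a benzyl on compound 1

The compounds below may be only part of what the source reports. "The series", "measured", "known", "first", "only" and "open" are said of these compounds alone.

Three hydroxamic acids have been measured in an assay on Sf9 cells for inhibition of protein deacetylase HDAC6 (Homo sapiens), read by fluorescence; on this read-out higher numbers stand for weaker inhibition and lower numbers for stronger inhibition. Compound 1 `O=C(NO)c1ccc(Cn2nnc(Cc3ccccc3)n2)cc1` gives 52 nM, which is the second highest of the three numbers. Among the measured compounds shown here, compound 3 `Cn1c(Sc2ccc(C(=O)NO)cc2)nnc1-c1cccs1` gives 8 nM, and compound 2 `Cc1cc(-c2nnc(Sc3ccc(C(=O)NO)c(F)c3)n2C)nn1C` gives 2240 nM; no step between any two of them differs in one place only, so these values stand side by side without a single-change comparison. The step now followed leads from compound 1 to compound 4 `O=C(NO)c1ccc(Cn2nnc(-c3ccccn3)n2)cc1`, where (pyridin-2-yl in place of benzyl on an aromatic carbon). For the measured compounds named here, no measured pair shows this change. The estimate for compound 4 expects a small step from compound 1, a 1.5-fold higher number from compound 1 to compound 4 (0.19 log units; within the scatter), which may not lie beyond the scatter. Compound 4 is therefore expected to give about 80 nM, within a range of 25 nM to 300 nM.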

Compound 4, half-maximal inhibitory concentration: 9 nM
Compound 4: the middle estimate sits 8.9-fold (0.95 log units) above what was measured; the whole stated range lies above it.
By their numbers in this assay, from the lowest: compounds 3 and 4 (each within the scatter of the next); then compound 1; then compound 2.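

Compound 1's benzyl, on the aromatic carbon of the five-membered ring with 4 nitrogen, is not the best group there: in this assay, pyridin-2-yl in its place gives a 5.8-fold lower number from compound 1 to compound 4 (0.76 log units; beyond the scatter). Among the compounds shown here, this is the first single-change comparison, and it shows that the number at this position responds to the group it carries. Nothing available explains why the number falls. The compounds shown do not separate the ring nitrogen from the loss of benzyl's methylene link. Plain phenyl, pyridin-3-yl and pyridin-4-yl at this position would address that question.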